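The source may hold more compounds than are shown below. What is called first, only, known or untested is meant among the compounds shown, and "the series" means these compounds.

Compound 1 `COc1ccc(/C=C/c2cc(OC)cc(OC)c2/C=C/C(=O)c2ccc(Cl)c(Cl)c2)cc1`: 10.8 ug/mL
Compound 2 `CCCC(C)Oc1ccc(C(=O)/C=C/c2c(/C=C/c3ccc(OC)cc3)cc(OC)cc2OC)cc1`: 11.1 ug/mL

In a functional assay on HepG2 cells (Homo sapiens) for antiproliferative activity, read by MTT assay, with a stated time of 48 h (a lower number here means a stronger inhibitor, a higher number a weaker inhibitor), compound 2 gives 11.1 ug/mL and compound 1 gives 10.8 ug/mL, so the two cannot be told apart. Compound 3 `COc1ccc(/C=C/c2cc(OC)cc(OC)c2/C=C/C(=O)c2ccc(C)cc2)cc1` is the next case. It carries methyl in place of 1-methylbutoxy on an aromatic carbon, para to a large group: methyl in place of 1-methylbutoxy on an aromatic carbon. Within the data shown here, only one measured step touches this part of the molecule, and it is a 1.0-fold higher number from compound 1 to compound 2 (0.01 log units; within the scatter). That exchange of 4-(1-methylbutoxy)phenyl for 3,4-dichlorophenyl left the number within the scatter, so no step beyond the scatter is expected here. Among the measured compounds shown here, this rests on a single step, and no compound with methyl at this place has been measured yet. The expected change is a 1.0-fold lower number from compound 2 to compound 3 (0.00 log units; within the scatter). For compound 3 the estimated value is 11 ug/mL, with an expected range from 5 ug/mL to 24 ug/mL.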

Compound 3, half-maximal inhibitory concentration: 4.8 ug/mL
Compound 3: middle estimate off by 2.3-fold (0.36 log units), on the high side, outside the stated range (below it).
By their numbers in this assay, from the lowest: compound 3; then compounds 1 and 2 (each within the scatter of the next).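

In this assay, the earlier exchange on this ring left the number within the scatter, so the group here could have seemed not to matter. Methyl now shows otherwise: replacing 1-methylbutoxy gives a 2.3-fold lower number from compound 2 to compound 3 (0.36 log units; beyond the scatter), and 4-methylphenyl in place of 3,4-dichlorophenyl gives a 2.3-fold lower number from compound 1 to compound 3 (0.35 log units; beyond the scatter), so both modest steps lie beyond the scatter and compound 3 stands apart from two otherwise very different compounds. Nothing available explains this gain for methyl.

Three compounds cannot show whether methyl itself is special or whether the two larger groups simply share a similar level by chance. An ethyl, a methoxy or an amine at the same place on the ring would show whether the number stays low, falls further or returns to the level of compound 1 and compound 2.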